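The compounds below may be only part of what the source reports. "The series", "measured", "known", "first", "only" and "open" are said of these compounds alone.

Measured compounds:
Compound 1, `COc1ccc(-c2cc(/C=C/C(=O)c3ccc(N)cc3)[nH]n2)cc1`: 85%
Compound 2, `COc1cc(-c2cc(/C=C/C(=O)c3ccc(N)cc3)[nH]n2)cc(OC)c1OC`: 88%
Compound 3, `COc1cc(-c2cc(/C=C/C(=O)c3ccc(F)c(F)c3)[nH]n2)cc(OC)c1OC`: 88%

All three were tested in a functional assay on MDA-MB-435 cells (Homo sapiens) for cytotoxicity, read by sulforhodamine B assay, with a stated time of 48 h, tested at 1 uM; on this read-out higher numbers stand for a weaker effect at the one concentration tested and lower numbers for a stronger effect. Compound 2 gives 88%, level with compound 3 and within the usual scatter of compound 1, so the three numbers cannot be told apart. Going by the values given here, the one step between neighbours, no change at the digits printed from compound 2 to compound 3 (within the scatter), concerns the group on the carbonyl carbon and leaves the read-out unchanged.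

Compound 4, `COc1ccc(-c2cc(/C=C/C(=O)c3ccc(N)cc3)[nH]n2)cc1OC`, is compound 2 with one change: hydrogen in place of methoxy on an aromatic carbon. Among the compounds with values here, no single step among the measured compounds alters a methoxy group alone, so the closest guide is the pair of compound 1 and compound 2, whose values differ only within the scatter although they carry different numbers of methoxy groups, and the step from compound 2 to compound 3, which showed no movement. Compound 4 is therefore expected to stay close to compound 2, the step of a number 2 percentage points lower from compound 2 to compound 4 (within the scatter) being within the scatter. The expected value for compound 4 is 86%, in the range 77% to 95%.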

Compound 4, a percentage reported as activity, at one concentration (the size of the read-out at that concentration, not a potency): 94%
Compound 4: middle estimate off by 8 percentage points, on the low side; measured number inside the range.
By their numbers in this assay, from the lowest: compounds 1, 2, 3 and 4 (each within the scatter of the next).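

In this assay, going by these compounds alone, hydrogen in place of methoxy on this aromatic carbon gives a number 6 percentage points higher from compound 2 to compound 4 (within the scatter) and offers the first direct look at this single position. Methoxy in place of hydrogen on an aromatic carbon gives a number 9 percentage points higher from compound 1 to compound 4 (within the scatter) and so neither exchange separates the compounds at the one concentration tested, which means that this position shows no measurable dependence on methoxy here. No measurement shown offers an explanation for these numbers.

The compounds shown leave open whether a different group on this carbon, such as an ethoxy chain or a carboxylic acid, would give a step beyond the scatter. They also leave open whether any of these compounds would have a stronger or weaker effect than another at a different concentration, as the readings show only the size of the effect at the one concentration tested.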